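Hydroxy in Place of Methoxymethyl on the Amine Chain

A few compounds are considered here, and "the series" means these few. Any claim that something is new, unique, unknown or untested is made for them only; others in the source may bear on it.

Within the data shown here, compound 2 `COCCCNC(=C\C(=O)/C=C/c1ccc(O)cc1)/C=C/c1ccc(O)cc1` was tested in a functional assay, read by spectrophotometry, with a stated time of 30 min (on this read-out lower numbers stand for an effect already at smaller amounts and higher numbers for an effect only at larger amounts of compound), and gave 130000 nM, the highest of the two numbers measured so far; the nearest is compound 1 `COc1cc(/C=C/C(=O)/C=C(/C=C/c2ccc(O)c(OC)c2)NCCCO)ccc1O`, which in this assay gives 27600 nM, a gap that lies beyond the scatter. Compound 3 `O=C(/C=C(/C=C/c1ccc(O)cc1)NCCO)/C=C/c1ccc(O)cc1` has not yet been measured. It differs from compound 2 in one place: hydroxy in place of methoxymethyl on a saturated chain carbon, two bonds along the chain from an amine nitrogen. Among the measured compounds shown here, no step between measured compounds covers this change, and compound 1 differs from compound 2 in more than one place, so the expectation rests on compound 2 alone. The estimate for compound 3 in this assay is 90000 nM, between 30000 nM and 300000 nM, a step of a 1.4-fold lower number from compound 2 to compound 3 (0.16 log units; within the scatter) expected to be small, toward lower numbers, and hardly beyond the scatter.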

Compound 3, half-maximal effective concentration: > 200000 nM
Compound 3: a limit, no number; the forecaster's own chance of this, stated with the estimate: 15%; middle value at least 2.2-fold (0.34 log units) from the limit.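

On the amine chain, hydroxy in place of methoxymethyl gives in this assay an at least 1.5-fold higher number from compound 2 to compound 3 (0.18 log units; that floor lies within the scatter), so this change brings no shift toward lower numbers at this position. Compound 3 gives a limit of the assay and not a number, so the size of the step stays unknown: the limit of > 200000 nM in this assay, at which 1 of the 3 values shown sits.

The compounds shown leave open how far the true number of compound 3 lies from its limit. They also leave open whether an amine or a carboxylic acid at this place, or a longer chain, would reach lower numbers.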